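Adding a methoxy group to a hydroxyphenyl compound

The compounds below may be only part of what the source reports. "The series", "measured", "known", "first", "only" and "open" are said of these compounds alone.

Measured in an ADME assay on NHDF cells (Homo sapiens) for cytotoxicity, read by MTT assay, with a stated time of 72 h; a lower number here means a stronger inhibitor, a higher number a weaker inhibitor:
- compound 1 `COc1ccc(/C=C2\CCC/C(=C\c3ccc(Cl)cc3)C2=O)cc1OC`: 11200 nM
- compound 2 `COc1ccc(/C=C2\CCC/C(=C\c3cccc(O)c3)C2=O)cc1OC`: 6800 nM
- compound 3 `COc1ccc(/C=C2\CCC/C(=C\c3ccc(O)cc3)C2=O)cc1OC`: 26100 nM

Compound 3 has the highest number of the three, making it the weakest inhibitor here. Compound 4 `COc1cc(/C=C2\CCC/C(=C\c3ccc(OC)c(OC)c3)C2=O)ccc1O` has methoxy in place of hydrogen on an aromatic carbon, ortho to a hydroxy group and meta to a large group, turning 4-hydroxyphenyl into 4-hydroxy-3-methoxyphenyl (methoxy in place of hydrogen on an aromatic carbon). Among the compounds with values here, no measured step adds this group. The closest guides are changes on the same ring: a 2.3-fold higher number from compound 1 to compound 3 (0.37 log units; beyond the scatter), and a 3.8-fold higher number from compound 2 to compound 3 (0.58 log units; beyond the scatter). Both are modest, so only a modest change is expected. The expected result is a 1.5-fold lower number from compound 3 to compound 4 (0.19 log units; within the scatter), probably toward the values of the other two compounds. For compound 4 the estimate is 17000 nM, with an expected range of 7000 nM to 40000 nM.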

Compound 4, half-maximal inhibitory concentration: 13700 nM
Beside the measured number, compound 4's estimate is 1.2-fold (0.09 log units) above it; measured number inside the range.
By their numbers in this assay, from the lowest: compounds 2, 1, 4 and 3 (each within the scatter of the next, the first and the last beyond it).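

In this assay, placing methoxy ortho to the hydroxy group gives a 1.9-fold lower number from compound 3 to compound 4 (0.28 log units; within the scatter), so this position takes the group with no shift beyond the scatter. Compound 4 also stays close to the other two compounds, with a 2.0-fold higher number from compound 2 to compound 4 (0.30 log units; within the scatter) and a 1.2-fold higher number from compound 1 to compound 4 (0.09 log units; within the scatter) as the steps. Nothing available here bears on the reason for this result. Still open, on these data alone, is whether an amine or an ethoxy group at this position would give a step beyond the scatter. Also open, as far as these compounds go, is whether methoxy would give a similar step on a ring without the hydroxy group.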